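A few compounds are considered here, and "the series" means these few. Any claim that something is new, unique, unknown or untested is made for them only; others in the source may bear on it.

Among the measured compounds shown here, the three compounds measured so far share one core and differ only in the aryl group carried on the amide-type nitrogen. Compound 1 `Cc1ccc(NC(=O)[C@H]2CN(C)C[C@@H]2c2ccc(/C=C/C(=O)Nc3ccccc3N)cc2)cc1` gives 62 mL/min/kg in an in vitro ADME assay on microsomes from liver (Mus musculus) for pharmacokinetics, read by LC-MS, with a stated time of 10 min, tested at 1 uM; a higher number here means faster removal of the compound, a lower number slower removal. Compound 2 `CN1C[C@H](C(=O)Nc2ccc(Br)cc2)[C@@H](c2ccc(/C=C/C(=O)Nc3ccccc3N)cc2)C1` carries bromo in place of methyl on an aromatic carbon, and in this assay compound 2 gives 16 mL/min/kg, a step of a 3.9-fold lower number from compound 1 to compound 2 (0.59 log units; beyond the scatter). Compound 3 `Cc1cc(NC(=O)[C@H]2CN(C)C[C@@H]2c2ccc(/C=C/C(=O)Nc3ccccc3N)cc2)ccc1F` differs from compound 1 by 4-fluoro-3-methylphenyl in place of 4-methylphenyl on an amide-type nitrogen; in this assay compound 3 gives 62 mL/min/kg, which is no change at the digits printed from compound 1 to compound 3 (within the scatter). The step between compound 2 and compound 3 is a 3.9-fold higher number from compound 2 to compound 3 (0.59 log units; beyond the scatter).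

Compound 4 `CN1C[C@H](C(=O)Nc2ccc(F)c(Br)c2)[C@@H](c2ccc(/C=C/C(=O)Nc3ccccc3N)cc2)C1` has not yet been measured. It differs from compound 3 by bromo in place of methyl on an aromatic carbon. This is the same kind of change as the earlier one, whose step was a 3.9-fold lower number from compound 1 to compound 2 (0.59 log units; beyond the scatter), but it is not the same change: in compound 2 the bromo stands para to a large group, whereas in compound 4 it stands ortho to a fluoro group and meta to a large group. For the measured compounds named here, only one earlier example of this kind of change exists, and its surroundings differ, so the range is kept wide. For compound 4 the expected step is a 3.1-fold lower number from compound 3 to compound 4 (0.49 log units; beyond the scatter), resting on the earlier step of a 3.9-fold lower number from compound 1 to compound 2 (0.59 log units; beyond the scatter). Compound 4 is therefore estimated at 20 mL/min/kg in this assay, within a range from 8 mL/min/kg to 45 mL/min/kg.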

Compound 4, clearance: 43 mL/min/kg
Estimate against measurement, compound 4: 2.2-fold (0.33 log units) below; measured number inside the range.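

Replacing methyl with bromo on the aryl group does not carry over by a fixed amount in this assay, since the size of the step differs between the two settings: the same change on two cores in this assay, a 3.9-fold lower number (0.59 log units; beyond the scatter) from compound 1 to compound 2 and a 1.4-fold lower number (0.16 log units; within the scatter) from compound 3 to compound 4, 2.7-fold (0.43 log units) apart, beyond the scatter of two such steps

The two other new steps fit this reading: the bromo compound with the fluoro group stands clearly apart from the bromo compound without it, a 2.7-fold higher number from compound 2 to compound 4 (0.43 log units; beyond the scatter), whereas the comparison with the first methyl compound shows no difference beyond the scatter, a 1.4-fold lower number from compound 1 to compound 4 (0.16 log units; within the scatter). With one pair on each side, this shows only that a drop seen on one aryl group cannot be assumed on another in these compounds; it does not show why the two steps differ, nor how the change would behave on any further aryl group, even though the step of a 1.4-fold lower number from compound 3 to compound 4 (0.16 log units; within the scatter) stays within the scatter.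

The compounds shown leave open whether a chloro or a trifluoromethyl group in the bromo position would follow the same course, and whether the gap between the steps would remain with a methoxy group or a nitrile in place of the fluoro group. They also leave open how the change would behave with an ethyl group in place of the methyl on the nitrogen of the shared core.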